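From carbonyl to 4-nitrobenzyl on the shared core

The source may report more compounds than this note shows. Statements on the series, on what has been measured and on what is new or still open speak of the compounds shown alone.

In a functional assay on A-375 cells (Homo sapiens) for antiproliferative activity, read by MTT assay, with a stated time of 24 h (on this read-out higher numbers stand for weaker inhibition and lower numbers for stronger inhibition), compound 1 `COc1cccc(C(=O)Oc2ccc3c(=O)c(-c4cc(OC)c(OC)cc4OC)coc3c2)c1` gives > 10000 nM, which is a limit and not a number. Compound 1 therefore stands at the limit of > 10000 nM in this assay, at which 1 of the 3 values shown sits.

The compound in view is compound 4 `COc1cc(OC)c(-c2coc3cc(OCc4ccc([N+](=O)[O-])cc4)ccc3c2=O)cc1OC`, not yet measured. Its difference from compound 1 is 4-nitrobenzyl in place of (3-methoxyphenyl)carbonyl on an oxygen on an aromatic ring; 4-nitrobenzyl stands in place of (3-methoxyphenyl)carbonyl on an oxygen on an aromatic ring.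

Two measured steps make the same kind of exchange at that place. Compound 2 `COc1cc(OC)c(-c2coc3cc(OCc4ccccc4F)ccc3c2=O)cc1OC` gives 2100 nM and compound 3 `COc1cc(OC)c(-c2coc3cc(OCc4ccc(F)cc4)ccc3c2=O)cc1OC` gives 1720 nM. These correspond to an at least 4.7-fold lower number from compound 1 to compound 2 (0.67 log units; beyond the scatter) and an at least 5.8-fold lower number from compound 1 to compound 3 (0.76 log units; beyond the scatter), and both are open-ended since they start from a limit. Moving the fluorine on the benzyl group changes little, with a 1.2-fold lower number from compound 2 to compound 3 (0.09 log units; within the scatter). No benzyl group carrying a nitro substituent has been measured, so the transfer to 4-nitrobenzyl rests on these two compounds alone.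

A step of similar size towards a lower number is therefore expected in this assay, with a wider margin than the two fluorinated compounds alone would suggest. The estimated change is an at least 4.0-fold lower number from compound 1 to compound 4 (0.60 log units; beyond the scatter). For compound 4 the expected value is 2500 nM, within an estimated range of 900 nM to 7000 nM.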

Compound 4, half-maximal inhibitory concentration: > 10000 nM
Compound 4 ended at the assay's limit; the forecaster's own chance of this, stated with the estimate: 12%; at least 4.0-fold (0.60 log units) between middle value and limit.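

In this assay, the gain seen with the fluorinated benzyl groups on this oxygen does not carry over to 4-nitrobenzyl: nitro in place of fluoro on an aromatic carbon gives an at least 5.8-fold higher number from compound 3 to compound 4 (0.76 log units; beyond the scatter), and 4-nitrobenzyl against 2-fluorobenzyl gives an at least 4.7-fold higher number from compound 2 to compound 4 (0.67 log units; beyond the scatter). A benzyl group on this oxygen is therefore not sufficient on its own, and the substituent on its ring matters here, even though moving the fluorine gave only a 1.2-fold lower number from compound 2 to compound 3 (0.09 log units; within the scatter). The value of compound 4 is a limit and not a number, and the step from compound 1 to compound 4 cannot be read, as both ends are limits: the limit of > 10000 nM in this assay, at which 2 of the 4 values shown sit.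

On these data alone, how far compound 4 lies beyond this limit stays open, so the full size of the change from fluoro to nitro is unknown. Also open, as far as these compounds go, is whether the drop belongs to nitro specifically or extends to other groups on that aromatic carbon, such as an amine, a carboxylic acid or a nitrile, and how a plain benzyl group without a substituent would compare with compound 2 and compound 3.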